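The source may hold more compounds than are shown below. What is called first, only, known or untested is meant among the compounds shown, and "the series" means these compounds.

Working notes on the series. Compound 1 `CC(C)(C)NS(=O)(=O)c1cccc(NC(=O)c2cccnc2N2CCC3(CC2)CC3)c1` is the measured starting point of this step. In an ADME assay on microsomes from liver (Homo sapiens) for metabolic stability, read by LC-MS, with a stated time of 40 min, tested at 0.5 uM (a higher number here means faster removal of the compound, a lower number slower removal), compound 1 gives > 399 mL.min-1.g-1, which is a limit of the assay and not a number. Compound 2 `COc1ccc(C(=O)Nc2cccc(S(=O)(=O)C3CCCC3)n2)c(N2CCC3(CC2)CC3)c1` likewise gives a limit in this assay, > 399 mL.min-1.g-1. Compound 3 `CC(C)(O)CNc1ccc(C(=O)Nc2cccc(S(=O)(=O)C3CCCC3)n2)c(N2CCC3(CC2)CC3)c1` also gives a limit in this assay, > 399 mL.min-1.g-1. Going by the values given here, the one measured step with a single change, a step that the two limits leave unreadable from compound 2 to compound 3, is therefore of unreadable size. All three measured values sit at the limit of > 399 mL.min-1.g-1 in this assay, at which 3 of the 3 values shown sit.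

Compound 4 `O=C(Nc1cccc(S(=O)(=O)C2CCCC2)c1)c1cccnc1N1CCC2(CC1)CC2` is not yet measured. It differs from compound 1 in one place: cyclopentyl in place of (tert-butyl)amino on a sulfonyl sulfur. Among the compounds with values here, compounds 2 and 3 already carry cyclopentylsulfonyl and return only a limit, and for compound 1 only a limit is known, so no measured step gives a readable size for this change. The step that the limit leaves unreadable from compound 1 to compound 4 is expected to be small or unreadable. For compound 4 the estimate in this assay is 500 mL.min-1.g-1, with a range from 250 mL.min-1.g-1 to 1000 mL.min-1.g-1, and the expectation is that the result is once more reported only as a limit.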

Compound 4, intrinsic clearance in microsomes: > 399 mL.min-1.g-1
Compound 4 gave a limit, no number; the forecaster's own chance of this, stated with the estimate: 75%; the middle value does not contradict the limit.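

In this assay compound 1 and compound 4 both return only a limit, so no step can be read for cyclopentyl in place of (tert-butyl)amino, and the compounds shown share one reading: the limit of > 399 mL.min-1.g-1 in this assay, at which 4 of the 4 values shown sit. What they leave open is how the four compounds rank in intrinsic clearance in microsomes, and which structural change, if any, alters it.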